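A few compounds are considered here, and "the series" means these few. Any claim that something is new, unique, unknown or untested is made for them only; others in the source may bear on it.

In an ADME assay on TZM cells (Homo sapiens) for cytotoxicity, read by XTT assay, with a stated time of 4 days (a higher number here means that more compound is tolerated, a lower number that less compound is tolerated), compound 1 `Cc1cc(N)cc(C)c1Oc1cc(Nc2ccc(C#N)cc2)c(N)cc1C(F)(F)F` gives 15800 nM. Compound 3 `CC(=O)/C=C/c1cc(C)c(Oc2cc(Nc3ccc(C#N)cc3)c(N)cc2C(F)(F)F)c(C)c1` gives > 8600 nM, which is a limit of the assay and not a number. Compound 2 `CNC(=O)c1cc(N)c(Nc2ccc(C#N)cc2)cc1Oc1c(C)cc(CCC#N)cc1C`, which bears a 2-cyanoethyl group, gives > 9100 nM, also a limit. Within the data shown here, compound 3 therefore has no exact place on the scale, and the one measured step, a step that the limit leaves unreadable from compound 1 to compound 3, offers no size to build on.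

Compound 4 `Cc1cc(CCC#N)cc(C)c1Oc1cc(Nc2ccc(C#N)cc2)c(N)cc1C(F)(F)F` differs from compound 3 by one change, 2-cyanoethyl in place of 2-acetylethenyl on an aromatic carbon. No shift beyond the usual scatter is expected in this assay. The expected step is a step that the limit leaves unreadable from compound 3 to compound 4. For compound 4 the estimated value is 10000 nM, with an expected range from 4000 nM to 25000 nM.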

Compound 4, half-maximal cytotoxic concentration: > 7100 nM
Compound 4 ended at the assay's limit (the forecaster's own chance of this, stated with the estimate: 60%); the middle value is on the limit's open side.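

Compound 4 also ends at a limit of the assay rather than a number, so its steps from compound 1, compound 2 and compound 3 cannot be read. The compounds shown leave open how far the true values of compound 2, compound 3 and compound 4 lie from one another and from compound 1 in this assay.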